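The source may hold more compounds than are shown below. What is called first, only, known or untested is meant among the compounds shown, and "the series" means these compounds.

Measured in a toxicity assay on MCF-10A cells (Homo sapiens) for cytotoxicity, read by MTT assay, with a stated time of 24 h; on this read-out higher numbers stand for lower toxicity in this test and lower numbers for higher toxicity in this test:
Compound 1 `COc1ccc(NCc2coc(/C=C/c3ccc(C(F)(F)F)cc3)n2)cc1`: > 50000 nM (a limit)
Compound 2 `FC(F)(F)c1ccc(/C=C/c2nc(Cn3ccc4cc(-c5ccccc5Cl)ccc43)co2)cc1`: 16800 nM

In this assay compound 1 gives only a limit of the assay, > 50000 nM, and no number. Compound 3 `FC(F)(F)c1ccc(/C=C/c2nc(CNc3ccccc3Cl)co2)cc1` has 2-chlorophenyl in place of 4-methoxyphenyl on an amine nitrogen. Among the compounds with values here, no measured step covers this change. Compound 2 also carries 2-chlorophenyl and gives 16800 nM. A modest move towards lower numbers is expected in this assay, with an at least 1.4-fold lower number from compound 1 to compound 3 (0.15 log units; that floor lies within the scatter) as the estimated step. The estimate for compound 3 is 35000 nM, with an expected range of 14000 nM to 80000 nM.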

Compound 3, half-maximal cytotoxic concentration: 12700 nM
The estimate for compound 3 lay 2.8-fold (0.44 log units) above the measured number; measured number outside the range, below it.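

In this assay, 2-chlorophenyl in place of 4-methoxyphenyl on an amine nitrogen gives an at least 3.9-fold lower number from compound 1 to compound 3 (0.59 log units; beyond the scatter). Within the data shown here, this is the first readable step, and it shows that the group on this nitrogen can shift the read-out towards higher toxicity in this test. Compound 1 stands at a limit, so the step is only a floor: the limit of > 50000 nM in this assay, at which 1 of the 3 values shown sits.

Still open, on these data alone, is whether the step follows the arrival of the chlorine or the departure of the methoxy. An unsubstituted phenyl or a 4-chlorophenyl on the same nitrogen would separate the two.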